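The source may report more compounds than this note shows. Statements on the series, on what has been measured and on what is new or still open speak of the compounds shown alone.

Compound 2, `CC(=O)Nc1ccc2nc(SCC(=O)NCc3ccc(Cl)cc3)sc2c1`, gives 6700 nM in a functional assay on HepG2 cells (Homo sapiens) for cytotoxicity, read by MTT assay, with a stated time of 48 h (a higher number here means a weaker inhibitor, a lower number a stronger inhibitor), the higher of the two numbers at hand; compound 1, `CNC(=O)CSc1nc2ccc(NC(=O)CCl)cc2s1`, gives 1900 nM in this assay, a lower number beyond the scatter. Compound 3, `CNC(=O)CSc1nc2ccc(NC(C)=O)cc2s1`, differs from compound 2 by hydrogen in place of 4-chlorophenyl on a saturated chain carbon bound to an amide-type nitrogen, cut one bond further out a 4-chlorobenzyl to methyl. Among the compounds with values here, no measured pair shows this change, so its effect is unknown; compound 1 shares the methyl amide but not the acetamide. The step from compound 2 to compound 3 in this assay is expected to be small, within the scatter, at a 1.3-fold lower number from compound 2 to compound 3 (0.13 log units; within the scatter). Compound 3 is therefore estimated at 5000 nM, between 2000 nM and 15000 nM.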

Compound 3, half-maximal inhibitory concentration: > 100000 nM
Compound 3 ended at the assay's limit; the forecaster's own chance of this, stated with the estimate: 20%; at least 20-fold (1.30 log units) between middle value and limit.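

In this assay compound 3 stands at a limit, not at a number: the limit of > 100000 nM in this assay, at which 1 of the 3 values shown sits. Hydrogen in place of 4-chlorophenyl on a saturated chain carbon bound to an amide-type nitrogen is a large change, with an at least 14-fold higher number from compound 2 to compound 3 (1.17 log units; beyond the scatter). Hydrogen in place of chloro on a saturated chain carbon bound to a carbonyl carbon is also large, with an at least 52-fold higher number from compound 1 to compound 3 (1.72 log units; beyond the scatter). On these data alone, it remains open whether an unsubstituted benzyl or a longer alkyl chain in place of 4-chlorobenzyl would restore a measurable number. As far as these compounds go, whether bromo could stand in for chloro also remains open.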